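Chloro for methoxy on the aromatic ring of compound 1

The source may hold more compounds than are shown below. What is called first, only, known or untested is meant among the compounds shown, and "the series" means these compounds.

Of the compounds shown here, three sharing one core have been measured so far in an in vivo ADME assay on the whole organism (plasma, strain Sprague-Dawley) for pharmacokinetics, with Rattus norvegicus as the target, at a dose of 1 mg/kg by the intravenous route (a higher number here means faster removal of the compound, a lower number slower removal), for this series. Compound 1 `COc1cc(C(=O)N2[C@@H](c3nccs3)[C@@H](C(N)=O)C[C@@]2(CC(C)C)C(=O)O)ccc1C(C)(C)C` gives 37 mL/min/kg there, the highest of the three numbers, while compound 2 `CCOC[C@H]1C[C@@](CC(C)C)(C(=O)O)N(C(=O)c2ccc(C(C)(C)C)c(OC)c2)[C@H]1c1nccs1` gives 5 mL/min/kg and compound 3 `COC[C@H]1C[C@@](CC(C)C)(C(=O)O)N(C(=O)c2ccc(C(C)(C)C)c(OC)c2)[C@H]1c1nccs1` gives 5 mL/min/kg on the same read-out. Both measured departures from the carbamoyl fall on a saturated ring carbon: ethoxymethyl in its place gives a 7.4-fold lower number from compound 1 to compound 2 (0.87 log units; beyond the scatter) as a modest step, and methoxymethyl gives a 7.4-fold lower number from compound 1 to compound 3 (0.87 log units; beyond the scatter) as another. Hydrogen in place of methyl on that side chain shows no change at the digits printed from compound 2 to compound 3 (within the scatter) and adds nothing further.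

Compound 4 `CC(C)C[C@@]1(C(=O)O)C[C@H](C(N)=O)[C@H](c2nccs2)N1C(=O)c1ccc(C(C)(C)C)c(Cl)c1` keeps the carbamoyl and differs from compound 1 on the aromatic ring instead: chloro in place of methoxy on an aromatic carbon in words, chloro in place of methoxy on an aromatic carbon, ortho to a tert-butyl group. Going by the values given here, no measured step touches that carbon, so the data set neither a size nor a direction for this change. The expectation therefore stays with compound 1 at 37 mL/min/kg as its starting point, and no step beyond the scatter is expected. The estimated step is a 1.4-fold lower number from compound 1 to compound 4 (0.14 log units; within the scatter) on this evidence. For compound 4 the estimate is 27 mL/min/kg with an expected range from 11 mL/min/kg to 60 mL/min/kg in this measure.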

Compound 4, clearance: 29 mL/min/kg
Compound 4: middle estimate off by 1.1-fold (0.03 log units), on the low side; the measured number falls inside the stated range.
By their numbers in this assay, from the lowest: compounds 2 and 3 (each within the scatter of the next); then compounds 4 and 1 (each within the scatter of the next).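

Going by these compounds alone, on the aromatic carbon ortho to a tert-butyl group, chloro in place of methoxy gives a 1.3-fold lower number from compound 1 to compound 4 (0.11 log units; within the scatter) in this assay, the first measured step at a position that the earlier compounds left untouched. Within the data shown here, in this small set, the single step on the aromatic carbon therefore stays within the scatter, whereas the two steps on the saturated ring carbon, a 7.4-fold lower number from compound 1 to compound 2 (0.87 log units; beyond the scatter) and a 7.4-fold lower number from compound 1 to compound 3 (0.87 log units; beyond the scatter), lie beyond it. No accompanying measurement bears on this result, so the data offer no explanation for it.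

With only chloro and methoxy shown on this aromatic carbon, it remains open whether a fluoro, a methyl, a trifluoromethyl or a longer ether such as ethoxy there would also stay within the scatter of compound 1. On these data alone, it also remains open whether chloro would give a similar step on the background of compound 2 or compound 3, where ethoxymethyl or methoxymethyl stands in place of the carbamoyl on the saturated ring carbon.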